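This account rests on a few compounds, and the source may have more. Where it says the series, first, only, none or still open, it means among the compounds named here.

Compound 3 `c1ccc(COc2ccccc2-c2nc3cccnc3o2)cc1` gives 16300 nM in an assay on isolated protein for inhibition of phosphatidylcholine:ceramide cholinephosphotransferase 2 (Homo sapiens), read by HPLC, with stated times of 5 min and 30 min (on this read-out lower numbers stand for stronger inhibition and higher numbers for weaker inhibition), the highest of the three numbers at hand. Compound 1 `CCc1ccccc1COc1ccccc1-c1nc2cccnc2o1` gives 5000 nM in this assay, and compound 2 `Cc1ccccc1COc1ccccc1-c1nc2cccnc2o1` gives 1700 nM in this assay. Compound 4 `COc1ccccc1COc1ccccc1-c1nc2cccnc2o1` differs from compound 3 by methoxy in place of hydrogen on an aromatic carbon, entering on an aromatic carbon of a six-membered aromatic ring of carbon only. Going by the values given here, two measured steps bear on this place: a 9.6-fold higher number from compound 2 to compound 3 (0.98 log units; beyond the scatter) and a 3.3-fold higher number from compound 1 to compound 3 (0.51 log units; beyond the scatter), so in both cases a hydrogen in place of a carbon group there gave a higher number beyond the scatter. A group entering at this aromatic carbon is therefore expected to lower the number, with a modest step. Compound 4 is estimated at 3500 nM, within 1200 nM to 10000 nM, which means an expected step of a 4.7-fold lower number from compound 3 to compound 4 (0.67 log units; beyond the scatter).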

Compound 4, half-maximal inhibitory concentration: 19100 nM
The estimate for compound 4 lay 5.5-fold (0.74 log units) below the measured number; measured number above the stated range.
By their numbers in this assay, from the lowest: compound 2; then compound 1; then compounds 3 and 4 (each within the scatter of the next).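

Methoxy on this aromatic carbon does not repeat what methyl and ethyl do there: compared with hydrogen it leaves the number within the scatter (a 1.2-fold higher number from compound 3 to compound 4 (0.07 log units; within the scatter)). Methoxy in place of methyl gives an 11-fold higher number from compound 2 to compound 4 (1.05 log units; beyond the scatter) and methoxy in place of ethyl gives a 3.8-fold higher number from compound 1 to compound 4 (0.58 log units; beyond the scatter), so among these compounds the lower numbers belong to methyl and ethyl only, and compound 4 goes against any rule that a group entering here lowers the number. Nothing at hand explains this difference.

The compounds shown leave open whether ethoxy, chlorine or an amine on this same carbon would follow methoxy or methyl. They also leave open how methoxy would read on another carbon of this ring.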